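This account rests on a few compounds, and the source may have more. Where it says the series, first, only, none or still open, it means among the compounds named here.

Measured in a functional assay on MGC-803 cells (Homo sapiens) for cytotoxicity, read by MTT assay, with a stated time of 48 h; a higher number here means a weaker inhibitor, a lower number a stronger inhibitor:
- compound 1, `CC1=NN(C(=O)COc2ccc(Cl)cc2)C(c2ccccc2O)C1`: "not active" (no number reported), with no number reported
- compound 2, `CC1=NN(C(=O)CCc2ccccc2)C(c2cc(Br)ccc2O)C1`: 21200 nM
- compound 3, `CNCC(=O)N1N=C(c2cc3ccccc3oc2=O)CC1c1ccccc1`: 12800 nM

Of the two compounds with a reported number, compound 3 has the lower one, yet its value and that of compound 2 lie within the usual scatter of each other, so the two cannot be placed in an order on this evidence. Compound 1 gave no number in this assay at all.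

Compound 4, `CCN(CC)C1CCN(CC(=O)N2N=C(c3cc4ccccc4oc3=O)CC2c2ccccc2)CC1`, keeps the core of compound 3 and differs from it in one place: 4-(diethylamino)piperidin-1-yl in place of methylamino on a saturated chain carbon bound to a carbonyl carbon. Among the compounds with values here, no measured pair in this set separates the effect of such a change, so there is no comparable step to lean on. Given the closeness of compound 2 and compound 3, the change is expected to move the number only modestly, if at all, in this assay. Compound 4 is therefore estimated at 8000 nM, within a range of 2500 nM to 25000 nM, which corresponds to an expected step of a 1.6-fold lower number from compound 3 to compound 4 (0.20 log units; within the scatter).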

Compound 4, half-maximal inhibitory concentration: 32400 nM
Compound 4: the middle estimate sits 4.1-fold (0.61 log units) below what was measured, outside the stated range (above it).
By their numbers in this assay, from the lowest: compounds 3, 2 and 4 (each within the scatter of the next, the first and the last beyond it).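

In this assay, within the data shown here, the exchange of methylamino for 4-(diethylamino)piperidin-1-yl on a saturated chain carbon bound to a carbonyl carbon gives a 2.5-fold higher number from compound 3 to compound 4 (0.40 log units; beyond the scatter) and so shows for the first time that the number responds to what this position carries. The change brings in more heavy atoms and a six-membered non-aromatic ring and removes the hydrogen-bond donor all at once, so this single step cannot tell which of these goes with the higher number. Nothing measured here offers an explanation for the step.

On these data alone, it remains open whether a small amine such as dimethylamino or a ring such as morpholin-4-yl would give a number nearer that of compound 3 or that of compound 4. As far as these compounds go, how a carboxylic acid or a longer chain at this position would read also remains open.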